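Swapping 3-ethylphenyl for 2-fluorophenyl on the amide

A few compounds are considered here, and "the series" means these few. Any claim that something is new, unique, unknown or untested is made for them only; others in the source may bear on it.

In a physicochemical assay for lipophilicity, read by mass spectrometry (a lower number here means a more polar compound, a higher number a more lipophilic compound), compound 2 (`CCc1cccc(NC(=O)C2Cc3cc(OC)c(OC)cc3C2=O)c1`) gives 3.11, the highest of the three numbers, ahead of compound 3 (`CCOc1cccc(NC(=O)C2Cc3cc(OC)c(OC)cc3C2=O)c1`) at 2.42 and compound 1 (`COc1cc2c(cc1OC)C(=O)C(C(=O)Nc1ccccc1)C2`) at 2.2. The next compound to be measured is compound 4 (`COc1cc2c(cc1OC)C(=O)C(C(=O)Nc1ccccc1F)C2`), which puts 2-fluorophenyl in place of 3-ethylphenyl on an amide-type nitrogen.

Going by the values given here, three measured steps bear on this change. Putting ethyl in place of hydrogen on an aromatic carbon gave a number 0.91 log units higher from compound 1 to compound 2 (beyond the scatter), a modest step beyond the scatter, and losing the ethyl group in compound 4 suggests a step of similar size in the opposite direction. Ethoxy in place of ethyl gave a number 0.69 log units lower from compound 2 to compound 3 (beyond the scatter), so a change at this group has already moved the number down once. Ethoxy in place of hydrogen gave only a number 0.22 log units higher from compound 1 to compound 3 (within the scatter), which is within the scatter, so not every added group shifts the number measurably. Among the compounds with values here, no measured compound carries fluorine, so that part of the change is a judgement, and only a small upward allowance is made for it.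

In this assay the expected step is a number 0.71 log units lower from compound 2 to compound 4 (beyond the scatter), a modest fall. For compound 4 the estimated value is 2.4, with an expected range from 2 to 2.8.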

Compound 4, partition coefficient: 2.36
Compound 4: middle estimate off by 0.04 log units, on the high side; the range from low to high includes it.
By their numbers in this assay, from the lowest: compounds 1, 4 and 3 (each within the scatter of the next); then compound 2.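

Going by these compounds alone, the fluorine adds little on its own: it gives a number 0.16 log units higher from compound 1 to compound 4 (within the scatter) in this assay and so joins ethoxy, whose step a number 0.22 log units higher from compound 1 to compound 3 (within the scatter) is also within the scatter, while ethyl, with a number 0.91 log units higher from compound 1 to compound 2 (beyond the scatter), remains the only one of the three groups on this phenyl ring to shift the number beyond the scatter. Exchanging the whole group on the amide-type nitrogen, 2-fluorophenyl in place of 3-ethylphenyl, gives a number 0.75 log units lower from compound 2 to compound 4 (beyond the scatter), which leaves compounds 1, 3 and 4 within the scatter of their neighbours in the ranking and compound 2 alone above them. No measurement shown here explains why these groups behave differently.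

Within the data shown here, with only three groups on this ring, each seen once, the compounds cannot show whether the rise seen with ethyl would continue with a longer chain such as butyl. Going by these compounds, how far the number would fall with an amine or a carboxylic acid on the same phenyl ring also remains open.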